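From Heptyl to Phenyl: Expecting Another Limit

The source may report more compounds than this note shows. Statements on the series, on what has been measured and on what is new or still open speak of the compounds shown alone.

Compound 3 `CCCCCCC[C@H]1C[C@H](Br)CCN1S(=O)(=O)c1ccc(C)cc1` is one of three compounds tested in a functional assay on A2780 cells (Homo sapiens) for antiproliferative activity, read by sulforhodamine B assay, with a stated time of 48 h; on this read-out lower numbers stand for stronger inhibition of growth and higher numbers for weaker inhibition of growth. In this assay, from the compounds shown here alone, compound 3 reaches only the limit > 100000 nM, so its true number is unknown. Compound 1 `CCCCCCC[C@H]1C[C@H](Cl)CCN1S(=O)(=O)c1ccc(C)cc1` likewise stops at the limit > 100000 nM. Compound 2 `Cc1ccc(S(=O)(=O)N2CC[C@@H](Cl)C[C@@H]2c2ccccc2)cc1` also stops at the limit > 100000 nM. Two measured steps exist, a step that the two limits leave unreadable from compound 1 to compound 2 and a step that the two limits leave unreadable from compound 1 to compound 3, and both are unreadable because of the limit of > 100000 nM in this assay, at which 3 of the 3 values shown sit. Compound 4 `Cc1ccc(S(=O)(=O)N2CC[C@@H](Br)C[C@@H]2c2ccccc2)cc1` differs from compound 3 by phenyl in place of heptyl on a saturated ring carbon. The same exchange, from compound 1 to compound 2, is the closest measured step, yet its size stays hidden behind the limits. No readable step supports any direction, so the expected step is a step that the limit leaves unreadable from compound 3 to compound 4, nothing beyond the scatter. Compound 4 is therefore estimated at 150000 nM, within 50000 nM to 500000 nM, most likely again as a limit.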

Compound 4, concentration for 50% growth inhibition: > 100000 nM
Compound 4 was reported as a limit; the forecaster's own chance of this, stated with the estimate: 85%; the middle value lies beyond the limit too.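

No step can be read from compound 3 to compound 4 or from compound 2 to compound 4, because all four compounds stop at the same limit: the limit of > 100000 nM in this assay, at which 4 of the 4 values shown sit.

The compounds shown leave open whether heptyl or phenyl, or chloro or bromo, makes any difference to growth inhibition.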